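A few compounds are considered here, and "the series" means these few. Any claim that something is new, unique, unknown or untested is made for them only; others in the source may bear on it.

Series notes. Compound 1 `O=C(CCCCC#Cc1cccnc1)c1ncc(-c2ccccn2)o1` and compound 2 `O=C(O)c1cccc(CCCCCCC(=O)c2ncc(-c3ccccn3)o2)c1` share the same core and differ in the chain and in the group at its end. In an assay for inhibition of Fatty-acid amide hydrolase 1 (Rattus norvegicus) (on this read-out lower numbers stand for stronger inhibition and higher numbers for weaker inhibition), compound 1 gives 300 nM. For compound 2 this assay reports only a limit, > 600 nM; this is a limit of the assay and not a number, so where compound 2 stands is known only to one side, as recorded in the limit of > 600 nM in this assay, at which 1 of the 2 values shown sits. Among the compounds with values here, of compound 1 and compound 2 the two values show only that compound 1 sits at a number while compound 2 sits at the limit; no step between them is given.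

Compound 3 `O=C(CCCCCCc1cccnc1)c1ncc(-c2ccccn2)o1` is not yet measured. It differs from compound 2 by pyridin-3-yl in place of 3-carboxyphenyl on a saturated chain carbon, six bonds along the chain from a carbonyl carbon. Compound 3 thus carries the same end group as compound 1, here on a saturated chain. A step from compound 2 to compound 3 toward lower numbers in this assay, beyond the scatter, is expected, since compound 1 with the same end group gives 300 nM. Compound 3 is estimated at 400 nM in this assay, within 120 nM to 1500 nM, which means an expected step of an at least 1.5-fold lower number from compound 2 to compound 3 (0.17 log units; that floor lies within the scatter).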

Compound 3, inhibition constant: 32 nM
Beside the measured number, compound 3's estimate is 13-fold (1.10 log units) above it; measured number outside the range, below it.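

In this assay, pyridin-3-yl in place of 3-carboxyphenyl on a saturated chain carbon, six bonds along the chain from a carbonyl carbon, gives an at least 18-fold lower number from compound 2 to compound 3 (1.27 log units; beyond the scatter), so the group at this position matters on the saturated chain. The size of that step is only a floor, because one end of it is a limit of the assay and not a number: the limit of > 600 nM in this assay, at which 1 of the 3 values shown sits.

With pyridin-3-yl held, 2-(pyridin-3-yl)ethyl in place of 2-(pyridin-3-yl)ethynyl on a saturated chain carbon, four bonds along the chain from a carbonyl carbon, gives a 9.4-fold lower number from compound 1 to compound 3 (0.97 log units; beyond the scatter), which shows that the chain also matters, a separation the earlier pair could not give since it differs in both chain and end group.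

From the compounds shown here alone, it remains open whether this reading is particular to pyridin-3-yl or would also hold for a plain phenyl, a pyridin-2-yl or a pyridin-4-yl group on the same saturated chain. Also open is how a shorter or a longer saturated chain ending in pyridin-3-yl would read in this assay, and the compounds shown give no cause for either step.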